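A Second Chloro on the Shared Core

The compounds below may be only part of what the source reports. "The series", "measured", "known", "first", "only" and "open" are said of these compounds alone.

Compound 1 `ClCc1cccc(Cn2cnc3c(Cl)ncnc32)c1` and compound 2 `ClCc1cccc(Cn2cnc3c(Cl)nc(Cl)nc32)c1` share one core and differ by a single chloro group, (chloro in place of hydrogen on an aromatic carbon). In a functional assay on RXF 393 cells (Homo sapiens) for cytotoxicity, read by sulforhodamine B assay, with a stated time of 48 h (a higher number here means a weaker inhibitor of growth, a lower number a stronger inhibitor of growth), compound 1 gives 24000 nM, while compound 2 gives 2090 nM, so the step of an 11-fold lower number from compound 1 to compound 2 (1.06 log units; beyond the scatter) makes the compound a considerably stronger inhibitor of growth.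

Compound 3 `ClCc1ccccc1Cn1cnc2ncnc(Cl)c21` is built from the same atoms as compound 1 but joined differently; how the two cores differ is not broken down here. In this assay compound 3 gives 6540 nM.

Compound 4 `ClCc1ccccc1Cn1cnc2nc(Cl)nc(Cl)c21` has not yet been measured. It relates to compound 3 as compound 2 relates to compound 1: chloro in place of hydrogen on an aromatic carbon. The place of the new chloro group is described in the same words for both pairs, so this is the same change, made on the core of compound 3 rather than that of compound 1.

Within the data shown here, the step from compound 3 to compound 4 is therefore expected to be about as large as the earlier one, a 9.3-fold lower number from compound 3 to compound 4 (0.97 log units; beyond the scatter), because the only measured example of this change is an 11-fold lower number from compound 1 to compound 2 (1.06 log units; beyond the scatter). Compound 4 is accordingly estimated at 700 nM, with a likely range from 250 nM to 2500 nM.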

Compound 4, concentration for total growth inhibition: 1900 nM
Compound 4: the middle estimate sits 2.7-fold (0.43 log units) below what was measured; measured number inside the range.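

In this assay, adding the chloro group again gives a lower number, a 3.4-fold lower number from compound 3 to compound 4 (0.54 log units; beyond the scatter), so the direction of the change carries over from the core of compound 1 to the core of compound 3. The size of the step does not carry over unchanged, and the gap between the two steps is larger than repeated measurements would be expected to produce: the same change on two cores in this assay, an 11-fold lower number (1.06 log units; beyond the scatter) from compound 1 to compound 2 and a 3.4-fold lower number (0.54 log units; beyond the scatter) from compound 3 to compound 4, 3.3-fold (0.52 log units) apart, beyond the scatter of two such steps. These two pairs show that a stronger inhibitor of growth resulted on both cores, but they do not show why the step is smaller on the core of compound 3, or whether a further core would follow either step.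

The compounds shown leave open whether a different group on that same aromatic carbon, such as an amine or a methoxy group, would lower the number as chloro does. They also leave open whether the two cores would show the same gap between these steps in other cell types.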